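A few compounds are considered here, and "the series" means these few. Any claim that something is new, unique, unknown or untested is made for them only; others in the source may bear on it.

Working notes on the series.

Compound 3 `O=C1[C@@H](NS(=O)(=O)c2cc3cccnc3s2)CCN1Cc1cc2[nH]cccc-2n1` gives 44% in an assay on isolated protein for inhibition of coagulation factor X (Oryctolagus cuniculus), tested at 1 uM; a lower number here means less inhibition, a higher number more inhibition at the concentration tested (going by the name of the read-out). Among the three measured compounds its number is the highest, but compound 2 `O=C1[C@@H](NS(=O)(=O)c2ccc(-c3ccc(Cl)s3)s2)CCN1Cc1cc2[nH]cccc-2n1` with 42% sits within the scatter of it, so no order can be claimed between those two. Compound 1 `O=C1[C@@H](NS(=O)(=O)c2cc3ccc(Cl)nc3s2)CCN1Cc1cc2[nH]cccc-2n1` gives 23%, and the single-point step a number 21 percentage points higher from compound 1 to compound 3 (beyond the scatter) is the only one in the set beyond the scatter.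

Compound 4 `O=C1[C@@H](NS(=O)(=O)c2ccc(-c3ccon3)s2)CCN1Cc1cc2[nH]cccc-2n1` is the next unmeasured member. It differs from compound 3 at the sulfonyl sulfur: a group of 10 heavy atoms (7 carbon, 1 nitrogen, 1 oxygen, 1 sulfur; one five-membered aromatic ring with 1 hetero atom, one five-membered aromatic ring with 2 hetero atoms) in place of a group of 9 heavy atoms (7 carbon, 1 nitrogen, 1 sulfur; one five-membered aromatic ring with 1 hetero atom, one six-membered aromatic ring with 1 hetero atom), on a sulfonyl sulfur.

Among the measured compounds shown here, no measured step bears directly on this change. The step from compound 1 to compound 3 concerns only a chloro on an aromatic carbon and says nothing about swapping a fused bicyclic for a linked pair of rings. The comparison of compound 2 and compound 3 shows that two quite different groups on the sulfonyl sulfur can land within the scatter of each other, which is the only hint available. The expectation for this assay is therefore no step beyond the scatter, with wide uncertainty, and a step of a number 6 percentage points lower from compound 3 to compound 4 (within the scatter) is taken as the central guess.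

Compound 4 is estimated at 38% in this assay, within 15% to 60%.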

Compound 4, a percentage reported as inhibition, at one concentration (the size of the read-out at that concentration, not a potency): 31%
For compound 4 the middle estimate is 7 percentage points above the measured one; the range from low to high includes it.
By their numbers in this assay, from the lowest: compounds 1 and 4 (each within the scatter of the next); then compounds 2 and 3 (each within the scatter of the next).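

In this assay the new result gives a number 13 percentage points lower from compound 3 to compound 4 (beyond the scatter) and a number 11 percentage points lower from compound 2 to compound 4 (beyond the scatter) so the group on the sulfonyl sulfur is not interchangeable, a point that the earlier pair of compound 2 and compound 3, within the scatter of each other, could not show. The second of these steps is the cleaner one, since it isolates 1,2-oxazol-3-yl in place of 5-chlorothiophen-2-yl on an aromatic carbon and shows that this single ring exchange alone is enough to move the number beyond the scatter, while a number 8 percentage points higher from compound 1 to compound 4 (within the scatter) allows no order between those two compounds despite their different groups on the sulfonyl sulfur. Nothing measured accounts for these steps.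

The compounds shown leave open whether a carboxylic acid, a primary amine or a methoxy group in place of 1,2-oxazol-3-yl on that aromatic carbon would land nearer compound 2 or nearer compound 4. They also leave open whether the differences seen at a single tested concentration would carry over to full potency values for these compounds.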